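Fluorine position on the aromatic-nitrogen substituent of compound 3

A few compounds are considered here, and "the series" means these few. Any claim that something is new, unique, unknown or untested is made for them only; others in the source may bear on it.

Measured so far in a functional assay on HepG2 cells (Homo sapiens) for cytotoxicity, read by MTT assay, with a stated time of 72 h; a lower number here means a stronger inhibitor, a higher number a weaker inhibitor:
- compound 1 `Cc1cc(=O)n(-c2ccccc2C(F)(F)F)nc1C(=O)Nc1ccc(Oc2ncnc3sccc23)cc1`: > 40000 nM, a limit of this assay, not a number
- compound 2 `Cc1cc(=O)n(-c2ccc(Br)cc2F)nc1C(=O)Nc1ccc(Oc2ncnc3sccc23)cc1`: 6300 nM
- compound 3 `Cc1cc(=O)n(-c2cccc(F)c2)nc1C(=O)Nc1ccc(Oc2ncnc3sccc23)cc1`: 18500 nM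

Among the two real numbers, compound 3 gives the highest; its nearest neighbour is compound 2, with a 2.9-fold higher number from compound 2 to compound 3 (0.47 log units; beyond the scatter). The third entry, for compound 1, is only a limit. Both steps out of compound 1, an at least 6.3-fold lower number from compound 1 to compound 2 (0.80 log units; beyond the scatter) and an at least 2.1-fold lower number from compound 1 to compound 3 (0.33 log units; beyond the scatter), run downward, and the comparison rests on (the limit of > 40000 nM in this assay, at which 1 of the 3 values shown sits).

Compound 4 `Cc1cc(=O)n(-c2ccc(F)cc2)nc1C(=O)Nc1ccc(Oc2ncnc3sccc23)cc1` differs from compound 3 by 4-fluorophenyl in place of 3-fluorophenyl on an aromatic nitrogen. For the measured compounds named here, no measured step moves a single fluorine around the ring in this way; the nearest comparison is compound 2, which also carries a substituent at the same position as the entering fluorine and sits lower than compound 3 by a 2.9-fold higher number from compound 2 to compound 3 (0.47 log units; beyond the scatter), though it also carries bromine rather than fluorine there and a second fluorine elsewhere. A small downward step is therefore expected, not clearly beyond the scatter: a 1.3-fold lower number from compound 3 to compound 4 (0.12 log units; within the scatter). Compound 4 is estimated at 14000 nM, with a likely range of 6000 nM to 35000 nM in this assay.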

Compound 4, half-maximal inhibitory concentration: 6460 nM
The estimate for compound 4 lay 2.2-fold (0.34 log units) above the measured number, within the range that was stated.
By their numbers in this assay, from the lowest: compounds 2 and 4 (each within the scatter of the next); then compound 3. At a limit, above all of these: compound 1.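

Moving the single fluorine from 3-fluorophenyl to 4-fluorophenyl on the aromatic nitrogen, with the atoms otherwise unchanged, is enough on its own to give a step beyond the scatter: a 2.9-fold lower number from compound 3 to compound 4 (0.46 log units; beyond the scatter). Compound 2 and compound 4 cannot be told apart, a 1.0-fold higher number from compound 2 to compound 4 (0.01 log units; within the scatter), so in this pair the bromine and second fluorine of compound 2 add nothing measurable over the 4-fluorophenyl group of compound 4. The step of an at least 6.1-fold lower number from compound 1 to compound 4 (0.79 log units; beyond the scatter) has no exact size, as compound 1 stands at a limit and not at a number: the limit of > 40000 nM in this assay, at which 1 of the 4 values shown sits.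

Open, on these data alone, is how a methoxy group, an amine or a carboxylic acid would compare with the fluorine of compound 4 on this ring. Also open, as far as these compounds go, is whether the step between 3-fluorophenyl and 4-fluorophenyl holds outside this assay.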